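Swapping pyridin-3-yl for thiophen-2-yl in compound 3

This account rests on a few compounds, and the source may have more. Where it says the series, first, only, none or still open, it means among the compounds named here.

In a functional assay on HUVEC cells (Homo sapiens) for inhibition, read by ELISA (a higher number here means a weaker inhibitor, a lower number a stronger inhibitor), compound 3 (`[O-][S+](Cc1ccccc1)c1nnc(-c2cccnc2)o1`) gives 8000 nM. Compound 1 (`[O-][S+](Cc1ccccc1)c1nnc(-c2ccncc2)o1`) gives 4000 nM, and compound 2 (`COc1c(C)cnc(C[S+]([O-])c2nnc(-c3ccccc3)o2)c1C`) gives 7000 nM. Compound 3 therefore stands within the usual scatter of both, so these numbers do not separate it from either one.

The next compound to be tested, compound 4 (`[O-][S+](Cc1ccccc1)c1nnc(-c2cccs2)o1`), differs from compound 3 in one place: thiophen-2-yl in place of pyridin-3-yl on an aromatic carbon. Thiophen-2-yl comes in place of pyridin-3-yl, on an aromatic carbon of a five-membered aromatic ring with 2 nitrogen and 1 oxygen.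

Going by the values given here, only one measured step changes this same place on an otherwise identical structure. It is a 2.0-fold higher number from compound 1 to compound 3 (0.30 log units; within the scatter), with pyridin-3-yl in place of pyridin-4-yl. Among the compounds with values here, compound 2 differs from compound 1 and compound 3 in more than one place, so it offers no such single step. Within the data shown here, no measured compound carries thiophen-2-yl, which makes this a thin guide. On the evidence of that one small step, no change beyond the scatter is expected in this assay, and no direction can be favoured with confidence. The estimated step is a 1.3-fold lower number from compound 3 to compound 4 (0.12 log units; within the scatter). Compound 4 is expected at 6000 nM, with an estimated range from 2500 nM to 14000 nM.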

Compound 4, half-maximal inhibitory concentration: 7000 nM
Beside the measured number, compound 4's estimate is 1.2-fold (0.07 log units) below it, within the range that was stated.
By their numbers in this assay, from the lowest: compounds 1, 2, 4 and 3 (each within the scatter of the next).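

Going by these compounds alone, until this result, the position had carried only two pyridine rings, and compound 4 is the first here to put a five-membered ring with sulfur as its hetero atom in place of a six-membered ring with nitrogen. In this assay, this swap gives a 1.1-fold lower number from compound 3 to compound 4 (0.06 log units; within the scatter), and measured against the other pyridine it gives a 1.8-fold higher number from compound 1 to compound 4 (0.24 log units; within the scatter), so the thiophen-2-yl compound cannot be told apart from either pyridine compound. Across these three groups, then, neither ring size nor a ring nitrogen at this position comes with a change beyond the scatter, and nothing available explains why.

On these data alone, all three groups are aromatic rings, so it remains open whether an amine, a carboxylic acid or a longer alkyl chain on this same carbon would move the number beyond the scatter. Also open, as far as these compounds go, is whether any group at this position can separate itself clearly from these compounds, given that every step here so far stays within the scatter.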